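Aryl exchange on the shared core: compound 2 to compound 3

The source may report more compounds than this note shows. Statements on the series, on what has been measured and on what is new or still open speak of the compounds shown alone.

compound 1 `CNCc1cc(-c2ccccc2)n(S(=O)(=O)c2ccccc2)c1`: 96%
compound 2 `CNCc1cc(-c2ccccc2C)n(S(=O)(=O)c2ccc(C)cc2)c1`: 92%

In a functional assay on the whole organism (strain Jcl:SD) for inhibition, with Rattus norvegicus as the target, with stated times of 3 min and 3 h, at a dose of 1 mg/kg by the intravenous route (on this read-out lower numbers stand for less inhibition and higher numbers for more inhibition at the one dose given (going by the name of the read-out)), compound 1 gives 96%, while compound 2 gives 92%. Compound 2 carries the lower of the two numbers, yet its gap to compound 1 lies within the scatter, so the two cannot be ordered. Compound 3 `CNCc1cc(-c2ccc(F)cc2)n(S(=O)(=O)c2ccc(C)cc2)c1` is the next structure, and it differs from compound 2 in one place: 4-fluorophenyl in place of 2-methylphenyl on an aromatic carbon. Within the data shown here, with no step between measured compounds available, little change beyond the scatter is expected in this assay, a step of a number 2 percentage points lower from compound 2 to compound 3 (within the scatter). Compound 3 is therefore estimated at 90%, in the range 75% to 98%.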

Compound 3, a percentage reported as inhibition, in the whole organism at one dose (the size of the read-out at that dose, not a potency): 86%
The estimate for compound 3 lay 4 percentage points above the measured number, within the range that was stated.
By their numbers in this assay, from the lowest: compounds 3, 2 and 1 (each within the scatter of the next).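

Among these compounds, the exchange of 2-methylphenyl for 4-fluorophenyl, on the aromatic carbon next to the ring nitrogen, gives the first single-place step on this core in this assay: a number 6 percentage points lower from compound 2 to compound 3 (within the scatter), so the two aryl groups cannot be ordered at this position. Inhibition at this one dose therefore stays in the same band with either group in place. Nothing available bears on this result.

As far as these compounds go, it remains open whether a carboxylic acid or an amine on this aryl ring would hold that inhibition. A single dose also leaves any difference in potency between compound 2 and compound 3 unresolved.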